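Working notes on a short series with one open compound

A few compounds are considered here, and "the series" means these few. Any claim that something is new, unique, unknown or untested is made for them only; others in the source may bear on it.

compound 1, `CC(C)N(C(=S)SCc1cc(=O)c2ccc(Cl)cc2o1)C(C)C`: in a functional assay on MCF7 cells (Homo sapiens) for antiproliferative activity, read by MTT assay, with a stated time of 72 h (on this read-out lower numbers stand for stronger inhibition and higher numbers for weaker inhibition), compound 1 gives > 25000 nM, a limit of the assay.
compound 2, `O=c1cc(CSC(=S)N2CCOCC2)oc2cc(Cl)ccc12`: in this assay compound 2 gives > 25000 nM, also a limit of the assay.
compound 3, `O=c1c(CSC(=S)N2CCOCC2)coc2ccccc12`: in this assay compound 3 gives 4000 nM, the only number in the set.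

Compound 1 and compound 2 share a core and differ by diisopropylamino in place of morpholin-4-yl on a thiocarbonyl carbon. The step that the two limits leave unreadable from compound 2 to compound 1 has no readable size because both values sit at the limit of > 25000 nM in this assay, at which 2 of the 3 values shown sit. The core of compound 3 differs from that of compound 2, but the difference between the two cores is not broken down here.

Compound 4, `CC(C)N(C(=S)SCc1coc2ccccc2c1=O)C(C)C`, is not yet measured. Against compound 3 it carries diisopropylamino in place of morpholin-4-yl on a thiocarbonyl carbon, the same change as that from compound 2 to compound 1. The earlier step gives no size, so the expectation for a 1.5-fold higher number from compound 3 to compound 4 (0.18 log units; within the scatter) is a step near zero, resting only on the value of compound 3, 4000 nM. Compound 4 is therefore estimated at 6000 nM, expected between 1500 nM and 25000 nM.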

Compound 4, half-maximal inhibitory concentration: > 30000 nM
Compound 4: no number, only a limit (the forecaster's own chance of this, stated with the estimate: 35%); middle value at least 5.0-fold (0.69 log units) away from the limit.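

In this assay compound 4 gives > 30000 nM, a limit of the assay and not a number. As far as these compounds go, on the core of compound 3, diisopropylamino in place of morpholin-4-yl on a thiocarbonyl carbon gives an at least 7.5-fold higher number from compound 3 to compound 4 (0.87 log units; beyond the scatter), so the change clearly weakens inhibition on this core, though the full size of the step stays unknown. The same change on the core of compound 2 cannot be read, so nothing shows that a step of this size carries from one core to the other: the limit of > 25000 nM in this assay, at which 2 of the 4 values shown sit.

Open, from the compounds shown here alone, is whether a smaller amine such as dimethylamino, or a piperazin-1-yl group, on a thiocarbonyl carbon would keep a measurable number on the core of compound 3. Also open, going by these compounds, is whether any such group would bring the core of compound 2 to a readable value.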